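A tert-Butyl for Benzyl Swap on the Saturated Ring Carbon

The source may hold more compounds than are shown below. What is called first, only, known or untested is meant among the compounds shown, and "the series" means these compounds.

Three compounds of this series have a result in a functional assay on MDA-MB-231 cells (Homo sapiens) for cytotoxicity, read by sulforhodamine B assay, with a stated time of 48 h; on this read-out lower numbers stand for higher toxicity in this test and higher numbers for lower toxicity in this test. Compound 1 `C=CC[C@@]12C[C@@H](C(=O)OC)N3[C@@H]1N(C(=N)[C@]3(Cc1ccccc1)N1CCCC1)c1ccc(Br)cc12` gives 18700 nM there. Compound 2 `COC(=O)[C@@H]1C[C@@]2(CC=C(C)C)c3ccccc3N3C(=N)C(C)(C)N1[C@H]32` gives 28300 nM in this assay. Compound 3 `COC(=O)[C@@H]1C[C@@]2(CC=C(C)C)c3ccccc3N3C(=N)[C@H](Cc4ccccc4)N1[C@H]32` returns only a limit in this assay, namely > 100000 nM, so its true value is not known. Compound 3 thus stands at the boundary of the assay's reporting range, (the limit of > 100000 nM in this assay, at which 1 of the 3 values shown sits), whereas compound 1 and compound 2 have definite numbers.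

Compound 4 `COC(=O)[C@@H]1C[C@@]2(CC=C(C)C)c3ccccc3N3C(=N)[C@H](C(C)(C)C)N1[C@H]32` is the untested analogue, and it differs from compound 3 by tert-butyl in place of benzyl on a saturated ring carbon. Among the measured compounds shown here, no measured pair differs in this one place alone, so the size of that step is open. Because the result for compound 3 is only a limit, > 100000 nM, any real value for compound 4 can at best be said to lie at or beneath it. Compound 4 is therefore expected to give about 70000 nM in this assay, with a range of 25000 nM to 200000 nM, and a real chance that only a limit is reported again. The expected step from compound 3 to compound 4, an at least 1.4-fold lower number from compound 3 to compound 4 (0.15 log units; that floor lies within the scatter), is estimated as a modest shift toward higher toxicity that may not clear the usual scatter.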

Compound 4, concentration lethal to 50% of the cells: 26200 nM
Compound 4: the middle estimate sits 2.7-fold (0.43 log units) above what was measured, within the range that was stated.
By their numbers in this assay, from the lowest: compounds 1, 4 and 2 (each within the scatter of the next). At a limit, above all of these: compound 3.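

In this assay, among the compounds shown here, tert-butyl in place of benzyl on a saturated ring carbon gives an at least 3.8-fold lower number from compound 3 to compound 4 (0.58 log units; beyond the scatter), the first step that isolates this position, and it shows that the group held there can change the read-out. Compound 3 gives > 100000 nM, which is a limit. The step therefore has a floor but no known size, and its full extent stays unresolved: the limit of > 100000 nM in this assay, at which 1 of the 4 values shown sits.

The compounds shown leave open whether the difference follows the loss of the aromatic ring or the change to a branched group, a question that a cyclohexylmethyl group on the same saturated ring carbon could address. As far as these compounds go, how an amine or a carboxylic acid at this carbon would read in this assay also remains open.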